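Tail amines in the series: the step to compound 4

This account rests on a few compounds, and the source may have more. Where it says the series, first, only, none or still open, it means among the compounds named here.

Compound 1 `COc1cc2c(Nc3ccc(C#N)cc3)ncnc2cc1OCCCN(C)Cc1ccccc1`: > 100000 nM (a limit of the assay)
Compound 2 `COc1cc2c(Nc3ccc(C#N)cc3)ncnc2cc1OCCCN1CCCC1`: 16200 nM
Compound 3 `CCOC(=O)C1CCN(CCCOc2cc3ncnc(Nc4ccc(C#N)cc4)c3cc2OC)CC1`: 34900 nM

All three values come from a functional assay on MCF7 cells (Homo sapiens) for antiproliferative activity, read by MTT assay, with a stated time of 72 h; on this read-out higher numbers stand for weaker inhibition and lower numbers for stronger inhibition. Compound 1 stands at a limit: the limit of > 100000 nM in this assay, at which 1 of the 3 values shown sits. Of the two actual numbers, the higher belongs to compound 3, at 34900 nM. Its nearest neighbour is compound 2, and the gap is a 2.2-fold higher number from compound 2 to compound 3 (0.33 log units; beyond the scatter).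

Compound 4 `COc1cc2c(Nc3ccc(C#N)cc3)ncnc2cc1OCCCN1CCC(N2CCCCC2)CC1` has not yet been measured. It keeps the core and chain of compound 3 and differs in one group: piperidin-1-yl in place of ethoxycarbonyl on a saturated ring carbon. In short, piperidin-1-yl stands in place of ethoxycarbonyl on a saturated ring carbon, turning 4-(ethoxycarbonyl)piperidin-1-yl into 4-(piperidin-1-yl)piperidin-1-yl.

Within the data shown here, no measured step makes this exact change. The closest guides are the swaps of the amine at the chain end. Two of these start from the limit of compound 1: an at least 6.1-fold lower number from compound 1 to compound 2 (0.79 log units; beyond the scatter) and an at least 2.8-fold lower number from compound 1 to compound 3 (0.45 log units; beyond the scatter). Among the measured compounds shown here, the only swap measured between two numbers is the modest one from compound 2 to compound 3, so only a small move in this assay, slightly towards a lower number, is expected. The expected step is a 1.6-fold lower number from compound 3 to compound 4 (0.20 log units; within the scatter). For compound 4 the estimated value is 22000 nM, with an expected range of 7000 nM to 70000 nM.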

Compound 4, half-maximal inhibitory concentration: 19600 nM
For compound 4 the middle estimate is 1.1-fold (0.05 log units) above the measured one, and the stated range covers the measured number.
By their numbers in this assay, from the lowest: compounds 2, 4 and 3 (each within the scatter of the next, the first and the last beyond it). At a limit, above all of these: compound 1.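

In this assay, piperidin-1-yl in place of ethoxycarbonyl on this saturated ring carbon gives a 1.8-fold lower number from compound 3 to compound 4 (0.25 log units; within the scatter), so this position accepts a ring-bearing amine group in place of an open-chain carbonyl group with no change that can be told from the scatter. The new tail also cannot be separated from the smaller pyrrolidin-1-yl tail, at a 1.2-fold higher number from compound 2 to compound 4 (0.08 log units; within the scatter), which leaves compound 4 within the scatter of both neighbours, although the modest gap of a 2.2-fold higher number from compound 2 to compound 3 (0.33 log units; beyond the scatter) lies beyond it. The benzyl(methyl)amino tail remains at a limit of the assay and not at a number, so the step of an at least 5.1-fold lower number from compound 1 to compound 4 (0.70 log units; beyond the scatter) gives only a bound: the limit of > 100000 nM in this assay, at which 1 of the 4 values shown sits.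

Still open, going by these compounds, is whether a carboxylic acid or a primary amine on this ring carbon, or a longer chain between the oxygen and the tail amine, would move the number in this assay beyond the scatter. On these data alone, all four compounds keep the nitrile and the shared core, so the effect of these tails with a chlorine in place of the nitrile also remains open.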